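The source may hold more compounds than are shown below. What is called first, only, known or untested is meant among the compounds shown, and "the series" means these compounds.

Compound 1 `O=C(CCCCCNc1c(NCc2ccccc2)c(=O)c1=O)NO`: < 4.8 uL/min
Compound 2 `CC[C@H](Nc1c(NCCCCCC(=O)NO)c(=O)c1=O)c1ccccc1`: < 5 uL/min
Compound 3 `Cc1ccccc1[C@H](C)Nc1c(NCCCCCC(=O)NO)c(=O)c1=O`: < 5 uL/min

In an ADME assay on cells (Hepatocyte, Homo sapiens) for pharmacokinetics, read by LC-MS, with a stated time of 90 min, tested at 1 uM (on this read-out higher numbers stand for fast clearance and lower numbers for slow clearance), compound 1 gives < 4.8 uL/min, which is a limit of the assay rather than a number. Compound 2 gives < 5 uL/min, also a limit. Compound 3 gives < 5 uL/min, likewise a limit. Compound 1 thus stands at the limit of < 4.8 uL/min in this assay, at which 1 of the 3 values shown sits. Compounds 2 and 3 stand at the limit of < 5 uL/min in this assay, at which 2 of the 3 values shown sit.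

Compound 4 `Cc1cccc(Nc2c(NCCCCCC(=O)NO)c(=O)c2=O)c1` has not yet been measured in this assay; it differs from compound 1 by 3-methylphenyl in place of benzyl on a nitrogen on an aromatic ring. Within the data shown here, the one step between measured compounds, a step that the two limits leave unreadable from compound 1 to compound 2, gives no readable size and concerns a different place, so nothing measured bears on this change directly. With compound 1 already at a limit, the step to compound 4 is expected to be a step that the limit leaves unreadable from compound 1 to compound 4, nothing beyond the scatter. Compound 4 is therefore estimated at 4 uL/min, between 2 uL/min and 10 uL/min, most likely again reported only as a limit.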

Compound 4, intrinsic clearance in a liver preparation (reported as CLH), per the amount of preparation that the assay uses: 18 uL/min
Beside the measured number, compound 4's estimate is 4.5-fold (0.65 log units) below it; the whole stated range lies below it.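

In this assay, among these compounds, putting 3-methylphenyl in place of benzyl on a nitrogen on an aromatic ring gives an at least 3.7-fold higher number from compound 1 to compound 4 (0.57 log units; beyond the scatter), the first readable step in this set. So this position can lift the read-out clear of the limit, even though the two groups have the same heavy-atom count. The value for compound 1 is only a limit, so the full size of the step stays unknown: the limit of < 4.8 uL/min in this assay, at which 1 of the 4 values shown sits.

From the compounds shown here alone, it remains open whether the rise goes with the methyl or with the loss of the benzyl carbon; plain phenyl or 3-methylbenzyl on the same nitrogen would separate the two. Going by these compounds, how a pyridyl ring would read here is also open.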